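The compounds below may be only part of what the source reports. "The series", "measured", "known", "first", "only" and "open" are said of these compounds alone.

Compound 1 `COc1ccc(NC(=O)NCCNS(=O)(=O)c2ccc(-c3ccccc3OCc3ccccc3)s2)cc1` is a urea that carries a 4-methoxyphenyl group, and it was tested in a functional assay on HeLa cells (Homo sapiens) for inhibition, read by CCK-8 assay, with a stated time of 48 h; on this read-out lower numbers stand for stronger inhibition and higher numbers for weaker inhibition. In this assay, compound 1 gives > 50000 nM, and this is a limit of the assay, not a number. Within the data shown here, compound 2 `O=S(=O)(NCCNC(=S)Nc1cc(C(F)(F)F)cc(C(F)(F)F)c1)c1cc(-c2ccccc2Oc2ccc(O)c(O)c2)cs1`, the only other compound with a result, gives > 20000 nM, and this too is only a limit. Neither result fixes a true potency, so compound 1 has no exact place on the scale.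

Compound 3 `O=C(NCCNS(=O)(=O)c1ccc(-c2ccccc2OCc2ccccc2)s1)Nc1cccc([N+](=O)[O-])c1` keeps the rest of compound 1 but has 3-nitrophenyl in place of 4-methoxyphenyl on an amide-type nitrogen. Among the measured compounds shown here, no measured pair shows what such a swap does in this assay. For the measured compounds named here, the only guide is compound 1 with its limit of > 50000 nM, so a large gain is not expected, and the result may again be only a limit. A modest step towards stronger inhibition is expected, and the estimate is an at least 1.2-fold lower number from compound 1 to compound 3 (0.09 log units; that floor lies within the scatter). For compound 3 the expected value is 40000 nM, with an estimated range from 12000 nM to 100000 nM.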

Compound 3, half-maximal inhibitory concentration: > 20000 nM
Compound 3 ended at the assay's limit (the forecaster's own chance of this, stated with the estimate: 65%); the middle value does not contradict the limit.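

In this assay compound 3 gives > 20000 nM, which is a limit of the assay and not a number. Among these compounds, compound 1 also stands at a limit, so no step between compound 1 and compound 3 can be read. The compounds shown leave open where either true potency lies and whether 3-nitrophenyl in place of 4-methoxyphenyl changes inhibition at all.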